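A Trifluoromethylphenyl in Place of the Iodophenyl

The source may report more compounds than this note shows. Statements on the series, on what has been measured and on what is new or still open speak of the compounds shown alone.

Of the compounds shown here, two sharing one core have been measured so far. Compound 1 `O=C(Nc1cccc(OCc2cn(-c3cccc(I)c3)nn2)c1)Nc1ccc(Cl)c(C(F)(F)F)c1` carries a 3-iodophenyl on an aromatic nitrogen; in a functional assay on HepG2 cells (Homo sapiens) for inhibition, read by MTT assay, with a stated time of 72 h (a lower number here means a stronger inhibitor, a higher number a weaker inhibitor), compound 1 gives 4780 nM. Compound 2 `O=C(Nc1cccc(OCc2cn(-c3ccc(I)cc3)nn2)c1)Nc1ccc(Cl)c(C(F)(F)F)c1` carries a 4-iodophenyl in that place, and in this assay compound 2 gives 2690 nM. For the measured compounds named here, the single known step is a 1.8-fold lower number from compound 1 to compound 2 (0.25 log units; within the scatter). On the numbers shown compound 2 therefore has the lowest value of the two, but its gap to compound 1 is within the scatter, so no order between them can be claimed.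

Compound 3 `O=C(Nc1cccc(OCc2cn(-c3cccc(C(F)(F)F)c3)nn2)c1)Nc1ccc(Cl)c(C(F)(F)F)c1` is not yet measured. It differs from compound 2 by 3-(trifluoromethyl)phenyl in place of 4-iodophenyl on an aromatic nitrogen. Going by the values given here, no measured step tests this exchange directly; the only step that bears on it, the exchange of a 3-iodophenyl for a 4-iodophenyl, was a 1.8-fold lower number from compound 1 to compound 2 (0.25 log units; within the scatter) and barely moved the number. With so little to go on, compound 3 is expected to stay close to compound 2, with an estimated step of a 1.3-fold higher number from compound 2 to compound 3 (0.11 log units; within the scatter) in this assay. Compound 3 is estimated at 3500 nM, with a range from 1200 nM to 10000 nM.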

Compound 3, half-maximal inhibitory concentration: 1270 nM
Estimate against measurement, compound 3: 2.8-fold (0.44 log units) above, and the stated range covers the measured number.
By their numbers in this assay, from the lowest: compound 3; then compounds 2 and 1 (each within the scatter of the next).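

In this assay, the comparison that changes only the group on the phenyl ring shows a 3.8-fold lower number from compound 1 to compound 3 (0.58 log units; beyond the scatter) when trifluoromethyl takes the place of iodo, and this step lies beyond the scatter, whereas the earlier exchange of 3-iodophenyl for 4-iodophenyl did not. The other new step, a 2.1-fold lower number from compound 2 to compound 3 (0.33 log units; beyond the scatter) and also beyond the scatter, changes both the group and the name of the phenyl substituent pattern, so it says less about trifluoromethyl alone. Both steps are modest, yet together they set compound 3 apart as the strongest inhibitor of the three, and nothing shown gives a reason for this.

The compounds shown leave open whether the lower number belongs to trifluoromethyl in particular or would also come with other groups on this phenyl ring, such as a nitrile, a methoxy group or an amine, or with a plain phenyl carrying no group at all. They also leave open whether the same exchange would lower the number in any test other than this one on HepG2 cells.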